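Aryl variation on the isoxazoline of the shared core

A few compounds are considered here, and "the series" means these few. Any claim that something is new, unique, unknown or untested is made for them only; others in the source may bear on it.

Measured compounds in a functional assay on DU-145 cells (Homo sapiens) for cytotoxicity, read by sulforhodamine B assay, with a stated time of 48 h; a higher number here means a weaker inhibitor, a lower number a stronger inhibitor:
compound 1, `C[C@H]1CC[C@@H]2[C@@H](OC(=O)[C@]23CC(c2c(Cl)cccc2Cl)=NO3)[C@]2(C)C(=O)C=C[C@@]12O`: 38000 nM
compound 2, `COc1ccc(C2=NO[C@]3(C2)C(=O)O[C@@H]2[C@H]3CC[C@H](C)[C@]3(O)C=CC(=O)[C@@]23C)cc1`: 20000 nM
compound 3, `C[C@H]1CC[C@@H]2[C@@H](OC(=O)[C@]23CC(c2ccc(N(C)C)cc2)=NO3)[C@]2(C)C(=O)C=C[C@@]12O`: 4500 nM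

Compound 1 stands at the highest of the three numbers in this assay. Its nearest neighbour is compound 2, with a 1.9-fold lower number from compound 1 to compound 2 (0.28 log units; within the scatter). The furthest is compound 3, with an 8.4-fold lower number from compound 1 to compound 3 (0.93 log units; beyond the scatter). Between the two aryl-substituted analogues the step is a 4.4-fold lower number from compound 2 to compound 3 (0.65 log units; beyond the scatter).

Compound 4, `COc1cc(C2=NO[C@]3(C2)C(=O)O[C@@H]2[C@H]3CC[C@H](C)[C@]3(O)C=CC(=O)[C@@]23C)ccc1O`, is not yet measured. It differs from compound 1 in one place: 4-hydroxy-3-methoxyphenyl in place of 2,6-dichlorophenyl on a carbon with a double bond to nitrogen

The step from compound 1 to compound 2 bears most directly on this change, as it also puts a methoxy-bearing phenyl in place of the dichlorophenyl, and it stayed within the scatter. The step from compound 1 to compound 3 shows that an aryl change at this position can lower the number beyond the scatter, but that analogue carries a dimethylamino group rather than a methoxy or hydroxy group, so it is a weaker guide. The expected outcome for compound 4 is therefore a small lowering at most, likely within the scatter, as a 2.1-fold lower number from compound 1 to compound 4 (0.32 log units; beyond the scatter). The estimated value for compound 4 in this assay is 18000 nM, with a range from 7000 nM to 45000 nM.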

Compound 4, half-maximal inhibitory concentration: 71000 nM
The estimate for compound 4 lay 3.9-fold (0.60 log units) below the measured number; the whole stated range lies below it.
By their numbers in this assay, from the lowest: compound 3; then compounds 2, 1 and 4 (each within the scatter of the next, the first and the last beyond it).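

In this assay, the 4-hydroxy-3-methoxyphenyl group shows that oxygen substitution on this aryl ring does not by itself carry a result in one direction: a 3.6-fold higher number from compound 2 to compound 4 (0.55 log units; beyond the scatter) is beyond the scatter, even though both compounds carry a methoxy-bearing phenyl on the carbon with a double bond to nitrogen, while a 1.9-fold higher number from compound 1 to compound 4 (0.27 log units; within the scatter) stays within it. The position therefore separates two closely related aryl groups, although 2,6-dichlorophenyl cannot be told apart from either of them, and a 16-fold higher number from compound 3 to compound 4 (1.20 log units; beyond the scatter) is the widest step yet seen here, leaving compound 3 with the 4-(dimethylamino)phenyl group as the strongest of the four. No measurement at hand accounts for these steps.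

The compounds shown do not separate the contribution of the hydroxy group from that of the methoxy group in compound 4, a question that 4-hydroxyphenyl and 3-methoxyphenyl analogues would address directly. Going by these compounds, it also remains open whether the low number of compound 3 is particular to dimethylamino or extends to other nitrogen groups such as a primary amine or a pyrrolidine on the same aryl ring.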